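A few compounds are considered here, and "the series" means these few. Any claim that something is new, unique, unknown or untested is made for them only; others in the source may bear on it.

Compound 1, `CC(C(=O)NCc1ccc(C(F)(F)F)nc1-c1ccccc1)c1ccc(NS(C)(=O)=O)c(F)c1`, gives 6.4 nM in an assay on CHO cells for antagonist activity at transient receptor potential cation channel subfamily V member 1 (Homo sapiens), read by FLIPR; a higher number here means a weaker inhibitor, a lower number a stronger inhibitor.
Compound 2, `CC(C(=O)NCc1ccc(C(F)(F)F)nc1-c1cccc(Cl)c1)c1ccc(NS(C)(=O)=O)c(F)c1`, gives 0.5 nM in this assay.
Compound 3, `CC(C(=O)NCc1ccc(C(F)(F)F)nc1-c1ccoc1)c1ccc(NS(C)(=O)=O)c(F)c1`, gives 1.4 nM in this assay.

Among these three, compound 1 has the highest number: compound 3 is nearest, with a 4.6-fold lower number from compound 1 to compound 3 (0.66 log units; beyond the scatter), and compound 2 is furthest, with a 13-fold lower number from compound 1 to compound 2 (1.11 log units; beyond the scatter). The step from compound 2 to compound 3 is a 2.8-fold higher number from compound 2 to compound 3 (0.45 log units; beyond the scatter).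

Compound 4, `Cc1ccc(CCc2nc(C(F)(F)F)ccc2CNC(=O)C(C)c2ccc(NS(C)(=O)=O)c(F)c2)cc1`, has not yet been measured in this assay. It differs from compound 1 in one place: 2-(4-methylphenyl)ethyl in place of phenyl on an aromatic carbon. Both measured steps out of compound 1 change the group at this same position, and both lowered the number, one modestly and one largely, so this position tolerates and even rewards change. Neither step, however, involves an ethyl chain between the core and the aromatic ring, so none of them speaks directly to the change in compound 4. Given that, compound 4 is expected to give about 5 nM in this assay, with a range from 1 nM to 25 nM, which means an expected step of a 1.3-fold lower number from compound 1 to compound 4 (0.11 log units; within the scatter), within or only slightly beyond the scatter.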

Compound 4, inhibition constant: 0.6 nM
The estimate for compound 4 lay 8.3-fold (0.92 log units) above the measured number, and the stated range ends above it.
By their numbers in this assay, from the lowest: compounds 2 and 4 (each within the scatter of the next); then compound 3; then compound 1.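

Putting 2-(4-methylphenyl)ethyl in place of phenyl on this aromatic carbon, next to the ring nitrogen, gives an 11-fold lower number from compound 1 to compound 4 (1.03 log units; beyond the scatter) in this assay and so shows that the position accepts a group of 9 heavy atoms, with an ethyl chain set between the core and the aromatic ring, and that the number still falls. The same group compares well with the furan-3-yl of the earlier series, with a 2.3-fold lower number from compound 3 to compound 4 (0.37 log units; beyond the scatter) as the result, while a 1.2-fold higher number from compound 2 to compound 4 (0.08 log units; within the scatter) leaves compound 4 and compound 2 level, so a chain-linked ring and a directly attached 3-chlorophenyl serve equally well here. Nothing measured accounts for this tolerance or for the gain over phenyl.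

The compounds shown leave open how much of the change belongs to the ethyl chain and how much to the methyl group on the ring, a split that a plain 2-phenylethyl group would settle. They also leave open how far the position reaches, which a longer chain such as 3-phenylpropyl would probe, and whether an amine or a carboxylic acid on the distant ring would be accepted.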